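Methyl in Place of Fluoro on a Saturated Ring Carbon

The source may hold more compounds than are shown below. What is called first, only, known or untested is meant among the compounds shown, and "the series" means these compounds.

Compound 1 `O=C(C1CCC(F)(F)CC1)N1CC(c2nc(-c3cccc(F)c3)no2)C1`: 520 nM
Compound 2 `O=C(N1CCC(F)CC1)N1CC(c2nc(-c3cccc(Cl)c3)no2)C1`: 990 nM
Compound 3 `Cc1cccc(-c2noc(C3CN(C(=O)c4ccccc4F)C3)n2)c1`: > 10000 nM

Three compounds sharing one core were measured in an assay on HEK293 cells for positive allosteric modulation of metabotropic glutamate receptor 5 (Homo sapiens), read by FLIPR; a higher number here means that more compound is needed for the effect, a lower number that less compound is needed. Compound 1 gives 520 nM, and compound 2 gives 990 nM, the higher of the two numbers, though the gap between them lies within the scatter of repeated measurements. For compound 3 the assay reports only a limit, (the limit of > 10000 nM in this assay, at which 1 of the 3 values shown sits), and no number.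

Compound 4 `CC1CCN(C(=O)N2CC(c3nc(-c4cccc(Cl)c4)no3)C2)CC1` has not yet been measured. It differs from compound 2 in one place: methyl in place of fluoro on a saturated ring carbon. In the words of the comparison, a 4-fluoropiperidin-1-yl becomes a 4-methylpiperidin-1-yl.

For the measured compounds named here, no measured pair in this set isolates this exchange, so no measured step can be pointed to. Fluoro and methyl each bring a single heavy atom and neither adds a donor, an acceptor or a charge, so the expected step in this assay is small and of no firm direction. Compound 4 is estimated at 900 nM, with a range from 300 nM to 3000 nM, which corresponds to an expected change of a 1.1-fold lower number from compound 2 to compound 4 (0.04 log units; within the scatter).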

Compound 4, half-maximal effective concentration: 865 nM
Compound 4: the middle estimate sits 1.0-fold (0.02 log units) above what was measured; the range from low to high includes it.
By their numbers in this assay, from the lowest: compounds 1, 4 and 2 (each within the scatter of the next). At a limit, above all of these: compound 3.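

In this assay, the exchange of fluoro for methyl on this saturated ring carbon, three ring bonds from the ring nitrogen, gives a 1.1-fold lower number from compound 2 to compound 4 (0.06 log units; within the scatter). For the compounds shown here, this is the first measured pair that isolates the change, and it shows that a 4-methylpiperidin-1-yl and a 4-fluoropiperidin-1-yl cannot be told apart in this assay when the rest of compound 2 is held fixed. Nothing measured here bears on what lies behind this result.

As far as these compounds go, whether the same ring carbon accepts a group of a different kind, such as a hydroxyl, an amine or a carboxylic acid, remains open. So does whether the exchange of fluoro for methyl would read the same with something other than the chlorine of compound 2 on the aromatic ring.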